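The compounds below may be only part of what the source reports. "The series", "measured", "known", "first", "only" and "open" are said of these compounds alone.

Measured in an ADME assay on L929 cells (Mus musculus) for cytotoxicity, read by resazurin assay, with a stated time of 48 h (on this read-out higher numbers stand for lower toxicity in this test and lower numbers for higher toxicity in this test), each value a limit of the assay:
- compound 1 `N#CCn1c2ccc([N+](=O)[O-])cc2c(=O)n1Cc1ccccc1`: > 256000 nM
- compound 2 `O=C(O)CCCn1c2ccc([N+](=O)[O-])cc2c(=O)n1Cc1ccccc1`: > 256000 nM
- compound 3 `O=c1c2cc([N+](=O)[O-])ccc2n(CCO)n1Cc1ccccc1`: > 256000 nM

Compound 3 gives > 256000 nM, which is a limit and not a number. It has no separate position in the series: the limit of > 256000 nM in this assay, at which 3 of the 3 values shown sit.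

The next structure is compound 4 `O=C(OCc1ccccc1)n1c2ccc([N+](=O)[O-])cc2c(=O)n1Cc1ccccc1`, with benzyloxycarbonyl in place of 2-hydroxyethyl on an aromatic nitrogen.

Within the data shown here, three measured steps bear on this change, since each alters the chain on an aromatic nitrogen. They are a step that the two limits leave unreadable from compound 1 to compound 3, a step that the two limits leave unreadable from compound 2 to compound 3 and a step that the two limits leave unreadable from compound 1 to compound 2. None of them has a readable size, so none gives a size to carry over. Among the measured compounds shown here, none of the measured compounds carries benzyloxycarbonyl, which leaves no direct guide to this group.

In this assay the estimate is therefore cautious, with a result at the same limit about as likely as a number. The expected step is an at least 1.2-fold lower number from compound 3 to compound 4 (0.10 log units; that floor lies within the scatter), small if readable at all, and it is expected to run toward lower numbers, meaning higher toxicity in this test.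

For compound 4 the estimated value is 200000 nM, with an expected range from 70000 nM to 256000 nM.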

Compound 4, concentration lethal to 50% of the cells: 86100 nM
The estimate for compound 4 lay 2.3-fold (0.37 log units) above the measured number; measured number inside the range.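

In this assay compound 4 is the only one of the compounds shown to give a number, 86100 nM. The group on this aromatic nitrogen can thus bring the read-out off the limit. Three steps lead to it, all beyond the scatter and all toward higher toxicity in this test: an at least 2.9-fold lower number from compound 3 to compound 4 (0.47 log units; beyond the scatter), an at least 2.9-fold lower number from compound 2 to compound 4 (0.47 log units; beyond the scatter) and an at least 2.9-fold lower number from compound 1 to compound 4 (0.47 log units; beyond the scatter). These sizes are one-sided, and the steps among compound 1, compound 2 and compound 3 cannot be read, so cyanomethyl, 3-carboxypropyl and 2-hydroxyethyl cannot be ranked against one another: the limit of > 256000 nM in this assay, at which 3 of the 4 values shown sit.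

With benzyloxycarbonyl as the only group of its kind, the compounds shown leave open whether the step follows the carbonyl on the aromatic nitrogen, the six-membered aromatic ring, or the two together. On these data alone, an ethoxycarbonyl group and a 2-phenylethyl chain on this nitrogen would separate those two parts, and the full size of each step stays open while the other three compounds remain at a limit.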